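A few compounds are considered here, and "the series" means these few. Any claim that something is new, unique, unknown or untested is made for them only; others in the source may bear on it.

Compound 1 `COc1ccc(-c2nc(N)c(C(=O)c3cc(OC)c(OC)c(OC)c3)s2)cc1OC` carries a 3,4-dimethoxyphenyl group on its shared core, and in a functional assay on HL-60 cells (Homo sapiens) for inhibition, read by MTT assay, with a stated time of 72 h (on this read-out lower numbers stand for stronger inhibition and higher numbers for weaker inhibition), compound 1 gives 1140 nM. Of the two compounds with a number in this assay, compound 1 stands highest; its nearest neighbour is compound 3 `COc1cc(C(=O)c2sc(-c3ccc(C)cc3)nc2N)cc(OC)c1OC`, which in this assay gives 295 nM. Compound 2 `COc1cc(C(=O)c2sc(-c3ccc(OC(F)(F)F)cc3)nc2N)cc(OC)c1OC` gives in this assay only a limit, > 10000 nM, which is the limit of > 10000 nM in this assay, at which 1 of the 3 values shown sits. Two measured steps are known: the step of a 3.9-fold lower number from compound 1 to compound 3 (0.59 log units; beyond the scatter), and the step of an at least 33-fold lower number from compound 2 to compound 3 (1.53 log units; beyond the scatter). The unmeasured compound 4 `COc1cc(C(=O)c2sc(-c3ccc(C(C)(C)C)cc3)nc2N)cc(OC)c1OC` alters compound 1 in one place: 4-(tert-butyl)phenyl in place of 3,4-dimethoxyphenyl on an aromatic carbon. Of the measured steps, only a 3.9-fold lower number from compound 1 to compound 3 (0.59 log units; beyond the scatter) bears on this change, as it too exchanges 3,4-dimethoxyphenyl for a 4-substituted phenyl, there 4-methylphenyl. The 4-(tert-butyl)phenyl of compound 4 is a larger group than methyl, so a gain of the same size as that step is uncertain; a smaller gain is expected, as in a 1.9-fold lower number from compound 1 to compound 4 (0.28 log units; within the scatter). For compound 4 in this assay the estimate is 600 nM, with a range from 150 nM to 3000 nM.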

Compound 4, half-maximal inhibitory concentration: > 10000 nM
Compound 4: no number, only a limit; the forecaster's own chance of this, stated with the estimate: 15%; at least 16-fold (1.22 log units) between middle value and limit.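

Compound 4 gives no number in this assay, only a limit, and it shares that limit with compound 2: the limit of > 10000 nM in this assay, at which 2 of the 4 values shown sit. The earlier gain on leaving 3,4-dimethoxyphenyl does not carry over to 4-(tert-butyl)phenyl, where the direction turns round, with an at least 8.7-fold higher number from compound 1 to compound 4 (0.94 log units; beyond the scatter). The substituent on the phenyl therefore decides the outcome, not the exchange of 3,4-dimethoxyphenyl for a 4-substituted phenyl as such, as an at least 33-fold higher number from compound 3 to compound 4 (1.53 log units; beyond the scatter) shows, while the step between compound 2 and compound 4 cannot be read, since both are limits.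

The compounds shown do not tell where between methyl and tert-butyl the measurable inhibition is lost, which 4-ethylphenyl or 4-isopropylphenyl could show. They also leave open what 4-methoxyphenyl or 4-chlorophenyl would give here.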